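The compounds below may be only part of what the source reports. "The series", "measured", "known", "first", "only" and "open" are said of these compounds alone.

In an ADME assay on the whole organism (Rattus norvegicus, strain Sprague-Dawley) for pharmacokinetics, using cassette dosing, at a dose of 1 mg/kg by the oral route (a higher number here means that a larger share of the oral dose reaches the circulation, a lower number that a smaller share of the oral dose reaches the circulation), compound 1 `O=C(Nc1ccc2[nH]c(=O)oc2c1)C(=O)N1CCN(c2ccc(C(F)(F)F)cc2)CC1` gives 24.8%. Compound 2 `O=C(Nc1ccc2[nH]c(=O)oc2c1)C(=O)N1CCN(c2ccc(F)c(Cl)c2)CC1` gives 24.6%, so the two compounds stand within the scatter of each other and neither is set apart. Compound 3 `O=C(Nc1ccc2[nH]c(=O)oc2c1)C(=O)N1CCN(c2ccc(C(F)(F)F)c(F)c2)CC1` keeps the core of compound 1 and alters a single place: fluoro in place of hydrogen on an aromatic carbon. Here fluoro takes the place of hydrogen on an aromatic carbon, ortho to a trifluoromethyl group and meta to a large group. Among the compounds with values here, no measured step makes this exact change. The closest evidence is the exchange of 4-(trifluoromethyl)phenyl for 3-chloro-4-fluorophenyl, which gave a number 0.2 percentage points lower from compound 1 to compound 2 (within the scatter). Within the data shown here, with that small step as the only guide, no change beyond the scatter is expected in this assay. The expected step is a number 0.2 percentage points higher from compound 1 to compound 3 (within the scatter). For compound 3 the estimated value is 25%, with an expected range from 13% to 38%.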

Compound 3, oral bioavailability: 8.7%
The estimate for compound 3 lay 16.3 percentage points above the measured number; measured number outside the range, below it.
By their numbers in this assay, from the lowest: compound 3; then compounds 2 and 1 (each within the scatter of the next).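

In this assay, fluoro in place of hydrogen on an aromatic carbon, ortho to a trifluoromethyl group and meta to a large group, gives a number 16.1 percentage points lower from compound 1 to compound 3 (beyond the scatter) and so moves the number beyond the scatter. The earlier exchange of 4-(trifluoromethyl)phenyl for 3-chloro-4-fluorophenyl gave a number 0.2 percentage points lower from compound 1 to compound 2 (within the scatter) and showed no such sensitivity, so this aromatic carbon is a place where a single fluoro can matter even though the earlier change of the ring's substituents left the number within the scatter. No measurement at hand speaks to what lies behind this step.

As far as these compounds go, how a methyl group, a methoxy group or a nitrile on that same aromatic carbon would read remains open. From the compounds shown here alone, it also remains open whether fluoro at this place would give a similar step on a ring without the trifluoromethyl group.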